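This account rests on a few compounds, and the source may have more. Where it says the series, first, only, none or still open, it means among the compounds named here.

Working notes on the series, read in a physicochemical assay for lipophilicity; a lower number here means a more polar compound, a higher number a more lipophilic compound. Compound 3 `c1ccc(COCCCOC2CCCCC2)cc1` gives 6.2, level with compound 1 `c1ccc(CCOC2CCCCC2)cc1` at 6.2, and these two together hold the highest of the three numbers. Compound 2 `c1ccc(CCON2CCCCC2)cc1` gives 4.8, which is the furthest from compound 3 and lies beyond the scatter.

The next member is compound 4 `c1ccc(COCCCON2CCCCC2)cc1`, not yet measured. The change is piperidin-1-yl in place of cyclohexyl on an oxygen on a saturated carbon. Among the compounds with values here, no measured step of this kind is available, so the expectation rests on the values alone. Compound 1 at 6.2 and compound 2 at 4.8 lie well apart, and a fall of similar size in this assay, beyond the scatter, is expected here. The expected step is a number 1.40 log units lower from compound 3 to compound 4 (beyond the scatter). For compound 4 the estimated value is 4.8, with an expected range from 4.2 to 5.4.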

Compound 4, partition coefficient: 4.8
Compound 4: the middle estimate sits on the measured number at the digits printed; measured number inside the range.
By their numbers in this assay, from the lowest: compounds 2 and 4 (each within the scatter of the next); then compounds 1 and 3 (each within the scatter of the next).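

In this assay the change of piperidin-1-yl in place of cyclohexyl on an oxygen on a saturated carbon now stands as a measured step: a number 1.40 log units lower from compound 3 to compound 4 (beyond the scatter) on this chain. Compound 4 at 4.8 stands level with compound 2 at 4.8 and compound 3 at 6.2 stands level with compound 1 at 6.2 in the same assay, so the two chains give the same numbers for each of these two ring groups, and none of the four compounds goes against this. No measurement at hand bears on why the step has this size.

Going by these compounds, whether a ring such as morpholin-4-yl on the same oxygen would give a number near that of piperidin-1-yl stays open. So does whether the step keeps its size on a longer chain.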